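The compounds below may be only part of what the source reports. "The series", "measured", "known", "first", "only" and "open" are said of these compounds alone.

Compound 1 `COc1ccc2[nH]c(C(=O)N3CC(=O)N(Cc4ccccc4)[C@@H](CN4CCCCC4)C3)cc2c1`: > 25000 nM
Compound 2 `O=C(c1cc2cc(C3CC3)ccc2[nH]1)N1CC(=O)N(Cc2ccccc2)[C@@H](CN2CCC(F)CC2)C1`: 12400 nM
Compound 3 `COc1cccc(CN2C(=O)CN(C(=O)c3cc4cc(OC)ccc4[nH]3)C[C@@H]2CCc2ccccc2)c1`: 5100 nM

All three compounds were run in a physicochemical assay for solubility, read by spectrophotometry, in phosphate buffer, with a stated time of 2 h, at pH 7.4; on this read-out higher numbers stand for higher solubility and lower numbers for lower solubility. Compound 1 returns > 25000 nM, which is a limit of the assay and not a number, so the read-out places it only at the top edge of what the assay reports (the limit of > 25000 nM in this assay, at which 1 of the 3 values shown sits). Compound 2 gives 12400 nM in this assay. Compound 3 gives 5100 nM in this assay. For the measured compounds named here, no two of the measured compounds differ in a single place, so no measured step is available as a guide.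

The compound still to be measured is compound 4 `COc1ccc2[nH]c(C(=O)N3CC(=O)N(Cc4ccccc4)[C@@H](CN4C(=O)c5ccccc5C4=O)C3)cc2c1`. It differs from compound 1 by a group of 11 heavy atoms (8 carbon, 1 nitrogen, 2 oxygen; one five-membered non-aromatic ring with 1 hetero atom, one six-membered aromatic ring of carbon only) in place of a group of 6 heavy atoms (5 carbon, 1 nitrogen; one six-membered non-aromatic ring with 1 hetero atom), on a saturated chain carbon bound to a saturated ring carbon. Going by the values given here, with no measured step to lean on, the expectation rests on the limit for compound 1 and on the fact that compounds 2 and 3 return numbers rather than limits. Compound 4 is expected to sit below the limit, a step of an at least 10-fold lower number from compound 1 to compound 4 (1.00 log units; beyond the scatter) relative to compound 1. The estimate for compound 4 in this assay is 2500 nM, with a range from 600 nM to 10000 nM.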

Compound 4, solubility: > 100000 nM
Compound 4: no number, only a limit (the forecaster's own chance of this, stated with the estimate: 10%); at least 40-fold (1.60 log units) between middle value and limit.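

In this assay compound 4 gives > 100000 nM, which is a limit and not a number. For the compounds shown here, compound 1 gives > 25000 nM, also a limit, so no step between the two can be read. The compounds shown leave open whether replacing the piperidin-1-yl group changes solubility, and in which direction.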